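The compounds below may be only part of what the source reports. "The series", "measured", "known", "first", "only" and "open" are said of these compounds alone.

Measured compounds:
compound 1 `COc1cccc(-c2cc(-c3cc(C(C)C)c(O)cc3C)[nH]c(=O)c2C#N)c1` gives 38% in a functional assay for inhibition, tested at 60 ug/mL; a lower number here means a weaker effect, a higher number a stronger effect of the compound at the concentration tested
compound 2 `COc1ccc(-c2cc(-c3cc(C(C)C)c(O)cc3C)[nH]c(=O)c2C#N)cc1` gives 43%
compound 3 `COc1ccc(-c2cc(-c3cc(C(C)C)c(O)cc3C)[nH]c(=O)c2C#N)cc1OC` gives 52%

Compound 3 carries the highest of the three numbers, but only its gap to compound 1 exceeds the scatter a number 14 percentage points higher from compound 1 to compound 3 (beyond the scatter); against compound 2 the difference remains within it a number 9 percentage points higher from compound 2 to compound 3 (within the scatter).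

Compound 4 `Cc1cc(O)c(C(C)C)cc1-c1cc(-c2ccccc2[N+](=O)[O-])c(C#N)c(=O)[nH]1` differs from compound 3 by 2-nitrophenyl in place of 3,4-dimethoxyphenyl on an aromatic carbon.

All measured steps concern methoxy groups on this same aryl ring: a number 5 percentage points higher from compound 1 to compound 2 (within the scatter) stays within the scatter, a number 9 percentage points higher from compound 2 to compound 3 (within the scatter) likewise, while a number 14 percentage points higher from compound 1 to compound 3 (beyond the scatter) is modest. None involves a nitro group, so they fix the position of the change but not the group entering; the two methoxy groups that leave had at most a modest share. The step is expected to be a number 12 percentage points lower from compound 3 to compound 4 (beyond the scatter). Compound 4 is estimated at 40%, with a range from 20% to 60%.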

Compound 4, a percentage reported as inhibition, at one concentration (the size of the read-out at that concentration, not a potency): 31%
Compound 4: the middle estimate sits 9 percentage points above what was measured; the measured number falls inside the stated range.
By their numbers in this assay, from the lowest: compounds 4, 1, 2 and 3 (each within the scatter of the next, the first and the last beyond it).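

The change reaches beyond methoxy placement: in this assay, 2-nitrophenyl at this position sits clearly under the 3,4-dimethoxyphenyl compound (a number 21 percentage points lower from compound 3 to compound 4 (beyond the scatter)) and the 4-methoxyphenyl compound (a number 12 percentage points lower from compound 2 to compound 4 (beyond the scatter)). It is not separated from the 3-methoxyphenyl compound (a number 7 percentage points lower from compound 1 to compound 4 (within the scatter)), so a non-methoxy aryl group at this position does not set itself apart from all the methoxy compounds.

Still open, going by these compounds, is what an amine or a carboxylic acid on this aryl ring would give, and whether the step belongs to the nitro group itself or to its place on the ring. Nothing at hand accounts for these steps.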